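The source may hold more compounds than are shown below. What is called first, only, known or untested is meant among the compounds shown, and "the series" means these compounds.

Measured so far:
compound 1, `Cc1nc(N)sc1CCCN/C(N)=N/C(=O)CCCCCCCCC(=O)/N=C(\N)NCCCc1sc(N)nc1C`, gives 0.53
compound 2, `Cc1nc(N)sc1CCCN/C(N)=N/C(=O)CCCCCCCCC(=O)/N=C(\N)NCCCc1cnc(N)s1`, gives 0.75

Both values come from an in vitro functional assay on Sf9 cells for agonist activity at histamine H2 receptor (Homo sapiens); on this read-out higher numbers stand for larger maximal responses and lower numbers for smaller maximal responses. Within the data shown here, compound 2 stands highest of the two numbers; the one known step, a number 0.22 higher from compound 1 to compound 2 (beyond the scatter), sets it apart from compound 1 beyond the scatter. Compound 3, `Cc1nc(N)sc1CCCN/C(N)=N/C(=O)CCCCCCCCC(=O)/N=C(\N)NCCCc1c[nH]cn1`, is not yet measured and differs from compound 2 in one place: 1H-imidazol-4-yl in place of 2-amino-1,3-thiazol-5-yl on a saturated chain carbon, three bonds along the chain from an amine nitrogen. Among the measured compounds shown here, no measured step touches this change; the single known step concerns a different place on the core and gives no guide to direction. The step is therefore expected to be a number 0.050 lower from compound 2 to compound 3 (within the scatter), with no direction assumed beyond the scatter. For compound 3 the estimate is 0.7, within 0.45 to 0.95.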

Compound 3, intrinsic activity: the largest response reached, as a fraction of the reference agonist's: 0.76
Compound 3: the middle estimate sits 0.060 below what was measured, within the range that was stated.
By their numbers in this assay, from the lowest: compound 1; then compounds 2 and 3 (each within the scatter of the next).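

In this assay the swap to 1H-imidazol-4-yl gives a number 0.010 higher from compound 2 to compound 3 (within the scatter) and so does not separate the two rings at this place on the chain. The same group in place of 2-amino-4-methyl-1,3-thiazol-5-yl gives a number 0.23 higher from compound 1 to compound 3 (beyond the scatter) and so is a second change at this place that lies beyond the scatter from compound 1. No data at hand bear on the reason for these results.

The other 2-amino-4-methyl-1,3-thiazol-5-yl group stays fixed in all three compounds. Going by these compounds, whether a pyridine ring or a longer chain at this place would give a similar response in this assay remains open.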